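Benzofuran amidoximes: halogen swap on the aniline ring

This account rests on a few compounds, and the source may have more. Where it says the series, first, only, none or still open, it means among the compounds named here.

Measured so far:
compound 1, `O/N=C(/Nc1cccc(Cl)c1)c1ccc2occc2c1` — 690 nM
compound 2, `O/N=C(/Nc1ccc(F)c(F)c1)c1ccc2occc2c1` — 22700 nM

In an assay on isolated protein for inhibition of Indoleamine 2,3-dioxygenase 1 (Homo sapiens), read by spectrophotometry (a lower number here means a stronger inhibitor, a higher number a weaker inhibitor), compound 2 gives the highest of the two numbers; compound 1 gives the lower one, and the gap between them lies beyond the scatter. Compound 3, `O/N=C(/Nc1ccc(F)c(Cl)c1)c1ccc2occc2c1`, differs from compound 2 by chloro in place of fluoro on an aromatic carbon. Among the measured compounds shown here, no step of exactly this kind is recorded, so the direction rests on compound 1, whose chloro-bearing ring gives 690 nM. A drop beyond the scatter is expected, an 11-fold lower number from compound 2 to compound 3 (1.05 log units; beyond the scatter). Compound 3 is estimated at 2000 nM, within 500 nM to 8000 nM.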

Compound 3, half-maximal inhibitory concentration: 5200 nM
Estimate against measurement, compound 3: 2.6-fold (0.41 log units) below; the range from low to high includes it.
By their numbers in this assay, from the lowest: compound 1; then compound 3; then compound 2.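

In this assay, chloro in place of fluoro on the aromatic carbon ortho to a fluoro group gives a 4.4-fold lower number from compound 2 to compound 3 (0.64 log units; beyond the scatter) and shows that this position responds to the identity of the halogen. Fluoro in place of hydrogen on an aromatic carbon gives a 7.5-fold higher number from compound 1 to compound 3 (0.88 log units; beyond the scatter) and shows that chloro alone does not set the number: the second halogen also shifts it. No measured evidence accounts for either step.

Open, as far as these compounds go, is how a bromo or methoxy group on the chloro-bearing carbon would read. Also open, from the compounds shown here alone, is whether the fluoro step holds when the shared core changes.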